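This account rests on a few compounds, and the source may have more. Where it says the series, first, only, none or still open, it means among the compounds named here.

Measured compounds:
compound 1, `CCc1ccc(N(CC(C)C)S(=O)(=O)c2ccc3c(c2)C(=O)CC(C2CCNCC2)O3)cc1`, 2.21
compound 2, `CCc1ccc(N(CC(C)C)S(=O)(=O)c2ccc3c(c2)C(F)CC(C2CCOCC2)O3)cc1`, 5.02
compound 3, `CC(C)CN(Cc1ccccc1C(F)(F)F)S(=O)(=O)c1ccc2c(c1)C(=O)CC(C1CCOCC1)O2`, 4.32

All three were run in a physicochemical assay for lipophilicity, at pH 7.4; a higher number here means a more lipophilic compound, a lower number a more polar compound. Compound 3 stands second highest of the three: compound 2 lies higher, beyond the scatter, and compound 1 lies well lower, also beyond the scatter. Going by the values given here, no single-point step between measured compounds is available, so the next change is judged from the structures alone.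

Compound 4, `CC(C)CN(c1ccc(F)cc1)S(=O)(=O)c1ccc2c(c1)C(=O)CC(C1CCOCC1)O2`, is the next compound for this assay. It differs from compound 3 in one place: 4-fluorophenyl in place of 2-(trifluoromethyl)benzyl on a sulfonamide nitrogen. The change removes the larger group and is expected to pull the value down by a step beyond the scatter, estimated as a number 0.92 log units lower from compound 3 to compound 4 (beyond the scatter). For compound 4 the value in this assay is estimated at 3.4, with a range from 2.8 to 4.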

Compound 4, distribution coefficient: 3.48
For compound 4 the middle estimate is 0.08 log units below the measured one; measured number inside the range.
By their numbers in this assay, from the lowest: compound 1; then compound 4; then compound 3; then compound 2.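

The sulfonamide nitrogen now has its first one-place comparison: in this assay, 4-fluorophenyl in place of 2-(trifluoromethyl)benzyl gives a number 0.84 log units lower from compound 3 to compound 4 (beyond the scatter), so this position can move the read-out with the rest of the structure held constant. The change swaps 11 heavy atoms for 7 with no change in donor, acceptor or charge counts. No measured evidence on the origin of the step is available.

This single pair cannot separate the benzyl link from the ring substituents. On these data alone, a plain benzyl group here would address that, while an amine on the ring remains untested ground.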